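Oxazolylmethyl in Place of Cyclobutylmethyl on Compound 1

The source may report more compounds than this note shows. Statements on the series, on what has been measured and on what is new or still open speak of the compounds shown alone.

Compound 1, `COc1cccc(-n2cc3nc(-c4cccnc4C)n(C[C@H]4CCCN(CC5CCC5)C4)c(=O)c3n2)c1`, in an assay on HEK293 cells for displacement of a labelled ligand from growth hormone secretagogue receptor type 1 (Homo sapiens), with a stated time of 60 min (a lower number here means a stronger inhibitor, a higher number a weaker inhibitor), gives 1.6 nM.
Compound 2, `Cc1ncccc1-c1nc2cn(-c3cccc(OC(F)F)c3)nc2c(=O)n1C[C@H]1CCCN(C[C@H]2CCCO2)C1`, in this assay gives 27 nM.
Compound 3, `COc1ccc(-n2cc3nc(-c4ccccc4C)n(CC4CCCN(C(C)C)C4)c(=O)c3n2)cc1`, in this assay gives 7.3 nM.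

Among the three measured compounds, compound 1 has the lowest number in this assay. Compound 3 stands higher, by a margin beyond the usual scatter, and compound 2 stands higher still, so compound 1 is the strongest inhibitor of the three on these numbers.

Compound 4, `COc1cccc(-n2cc3nc(-c4cccnc4C)n(C[C@H]4CCCN(Cc5cnco5)C4)c(=O)c3n2)c1`, is the untested partner of compound 1. The change is 1,3-oxazol-5-yl in place of cyclobutyl on a saturated chain carbon bound to an amine nitrogen in a ring. The rest of the molecule, including the shared core and its two aryl substituents, stays as in compound 1.

Within the data shown here, no pair of measured compounds differs in the substituent on this ring nitrogen, so the size of the step cannot be read off from the data. The author expects a small loss of potency for compound 4, a step that may sit at the edge of the scatter or just beyond it. The step from compound 1 to compound 4 is estimated as a 2.2-fold higher number from compound 1 to compound 4 (0.34 log units; beyond the scatter). Compound 4 is therefore expected to give about 3.5 nM in this assay, within a range from 0.9 nM to 14 nM.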

Compound 4, half-maximal inhibitory concentration: 120 nM
Estimate against measurement, compound 4: 34-fold (1.54 log units) below; measured number above the stated range.
By their numbers in this assay, from the lowest: compound 1; then compound 3; then compound 2; then compound 4.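

In this assay, the group on the saturated chain carbon bound to an amine nitrogen in a ring proves to be a sensitive point: with the shared core and its two aryl substituents unchanged, 1,3-oxazol-5-yl in place of cyclobutyl gives a 75-fold higher number from compound 1 to compound 4 (1.88 log units; beyond the scatter), a large step beyond the scatter. The earlier compounds shown here offered no comparison at this position, and this first one shows that a four-membered non-aromatic ring of carbon only and a five-membered aromatic ring with 2 hetero atoms are far from interchangeable here, although they differ by only one heavy atom. Nothing available explains this loss of potency.

As far as these compounds go, only these two groups are compared at this position on an otherwise identical molecule, so it remains open whether the loss is specific to 1,3-oxazol-5-yl or extends to other aromatic rings. A phenyl or cyclopentyl group in the same place could help separate those possibilities, and it is also unknown whether the step would keep its size with different aryl substituents on the shared core.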